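Ethyl in Place of Hydrogen: Expected Cytotoxicity of Compound 3

The source may hold more compounds than are shown below. What is called first, only, known or untested is meant among the compounds shown, and "the series" means these compounds.

Among the compounds with values here, compound 1, `CC[C@H](CCn1cncn1)c1ccc(OC)cc1`, stands highest of the two numbers so far in an ADME assay on RD cells (Homo sapiens) for cytotoxicity, read by MTT assay, with a stated time of 3 days (on this read-out higher numbers stand for lower toxicity in this test and lower numbers for higher toxicity in this test), where compound 1 gives 118 ug/mL. Its mirror image, compound 2, `CC[C@@H](CCn1cncn1)c1ccc(OC)cc1`, gives 115 ug/mL in this assay. Within the data shown here, the only measured step, a 1.0-fold lower number from compound 1 to compound 2 (0.01 log units; within the scatter), lies within the scatter, which sits well with the fact that compounds 1 and 2 differ only in the configuration as drawn. Both compounds therefore show weak cytotoxicity at much the same level.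

The unmeasured compound 3, `CCCC[C@H](CCn1cncn1)c1ccc(OC)cc1`, differs from compound 1 by ethyl in place of hydrogen on a saturated chain carbon, three bonds along the chain from an aromatic carbon. Among the measured compounds shown here, no measured step touches a change of this kind: the single step in hand concerns configuration alone and says nothing about lengthening the chain. What can be drawn from the two measured compounds is only that this assay has so far given high, near-identical numbers for the shared core, so a step of modest size is expected for compound 3, most likely toward a somewhat lower number, as a 1.2-fold lower number from compound 1 to compound 3 (0.09 log units; within the scatter) expresses, though a step no larger than the scatter remains quite possible. On this basis compound 3 is estimated at 95 ug/mL in this assay, with a likely range from 45 ug/mL to 200 ug/mL.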

Compound 3, half-maximal cytotoxic concentration: 28.3 ug/mL
Beside the measured number, compound 3's estimate is 3.4-fold (0.53 log units) above it, and the stated range ends above it.
By their numbers in this assay, from the lowest: compound 3; then compounds 2 and 1 (each within the scatter of the next).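

Within the data shown here, at this position the chain is not a silent place in this assay: ethyl in place of hydrogen on the saturated chain carbon, three bonds along the chain from an aromatic carbon, gives a 4.2-fold lower number from compound 1 to compound 3 (0.62 log units; beyond the scatter), whereas the one earlier step, a change of configuration alone, was a 1.0-fold lower number from compound 1 to compound 2 (0.01 log units; within the scatter). Read one bond further out, the same difference is ethyl to butyl, so lengthening this chain goes with higher toxicity in this test, which the earlier pair of mirror images could not show. Among these compounds, nothing at hand gives a reason for this step, since the only information offered concerns configuration and does not bear on chain length.

What the compounds shown leave open is the shape of the trend, with a single step at this position: a propyl chain might fall anywhere between ethyl and butyl, a longer chain such as hexyl might lower the number further or not, and an amine or a hydroxyl at the chain end could behave quite differently. They also leave open whether configuration at this carbon stays without effect once the chain is butyl.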